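Cytotoxicity notes on a hydrazone-urea series in fibroblasts

The source may report more compounds than this note shows. Statements on the series, on what has been measured and on what is new or still open speak of the compounds shown alone.

Measured compounds:
compound 1 `CN(C)CCn1cnnc1-c1cc(Oc2ccc(NC(=O)N/N=C/c3ccccc3O[N+](=O)[O-])cc2F)ccn1` — 6860 nM
compound 2 `CN(C)CCn1cnnc1-c1cc(Oc2ccc(NC(=O)N/N=C/c3ccc(O)c(O)c3)cc2F)ccn1` — "not determined" (no result reported)

In an ADME assay on WI-38 cells (Homo sapiens) for cytotoxicity, read by MTT assay, with a stated time of 72 h (on this read-out higher numbers stand for weaker inhibition and lower numbers for stronger inhibition), compound 1 gives 6860 nM. Compound 2 carries a 3,4-dihydroxyphenyl group on the carbon with a double bond to nitrogen; in this assay compound 2 gives "not determined" (no result reported), so no number stands for it and nothing can be read from the pair with compound 1 beyond what compound 1 shows on its own.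

Compound 3 `CN(C)CCn1cnnc1-c1cc(Oc2ccc(NC(=O)N/N=C/c3ccc(Cl)cc3)cc2F)ccn1` is not yet measured. Relative to compound 2 the change is 4-chlorophenyl in place of 3,4-dihydroxyphenyl on a carbon with a double bond to nitrogen; the rest of the shared core is unchanged. Among the measured compounds shown here, with no step between measured compounds to lean on, the only anchor is the single number for compound 1. For compound 3 the step from compound 2 cannot be sized, and the expectation is a value in this assay in the same region as that of compound 1, with no shift beyond the scatter claimed in either direction. Compound 3 is expected at 6000 nM, with a range of 2000 nM to 20000 nM.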

Compound 3, half-maximal inhibitory concentration: 1870 nM
For compound 3 the middle estimate is 3.2-fold (0.51 log units) above the measured one; measured number below the stated range.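

In this assay, among the compounds shown here, 4-chlorophenyl in place of 2-(nitrooxy)phenyl on a carbon with a double bond to nitrogen gives a 3.7-fold lower number from compound 1 to compound 3 (0.56 log units; beyond the scatter), the first sized step. It shows that the group at this position can move the number beyond the scatter while the rest of the shared core stays unchanged, and the direction of this step is towards stronger inhibition. The step from compound 2 to compound 3 cannot be read, as compound 2 has no number, and no measurement here bears on the reason for the step that can be read.

On these data alone, a single step gives a direction for this one exchange only, so it remains open whether the lower number goes with the chlorine of compound 3 or with the loss of the 2-(nitrooxy)phenyl group of compound 1. Plain phenyl, 4-fluorophenyl or 4-methoxyphenyl at the same position would help separate these two readings, and the standing of 3,4-dihydroxyphenyl against either measured group also remains unknown.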